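The source may hold more compounds than are shown below. What is called first, only, known or untested is meant among the compounds shown, and "the series" means these compounds.

The measured compounds in an assay on Prostate gland for inhibition of steroid 5-alpha-reductase (Rattus norvegicus); on this read-out higher numbers stand for weaker inhibition and lower numbers for stronger inhibition:
compound 1 `CCC(c1ccccc1)n1ccc2cc(/C(C)=C/C(=O)Nc3ccccc3OCCCC(=O)O)ccc21` gives 19 nM;
compound 2 `CCCCCC(c1ccccc1)n1ccc2cc(/C(C)=C/C(=O)Nc3ccccc3OCCCC(=O)O)ccc21` gives 25 nM;
compound 3 `COc1ccc(C(c2ccccc2)n2ccc3cc(/C(C)=C/C(=O)Nc4ccccc4OCCCC(=O)O)ccc32)cc1` gives 8.8 nM.

Among these three, compound 3 stands lowest: a 2.2-fold lower number from compound 1 to compound 3 (0.33 log units; beyond the scatter) and a 2.8-fold lower number from compound 2 to compound 3 (0.45 log units; beyond the scatter) are both beyond the scatter, while a 1.3-fold higher number from compound 1 to compound 2 (0.12 log units; within the scatter) stays within it. Compound 4 `C/C(=C\C(=O)Nc1ccccc1OCCCC(=O)O)c1ccc2c(ccn2C(c2ccccc2)c2ccc(C(F)(F)F)cc2)c1` has not yet been measured. It differs from compound 3 in one place: trifluoromethyl in place of methoxy on an aromatic carbon, placed on an aromatic carbon of a six-membered aromatic ring of carbon only, para to a large group. For the measured compounds named here, no measured step exchanges a substituent on that ring. Going by the values given here, the steps that bear on it, a 2.2-fold lower number from compound 1 to compound 3 (0.33 log units; beyond the scatter) and a 2.8-fold lower number from compound 2 to compound 3 (0.45 log units; beyond the scatter), swap the whole group on the saturated chain carbon bound to an aromatic carbon and an aromatic nitrogen, and both are modest in size. A change that only exchanges one substituent on the 4-methoxyphenyl ring is therefore expected to give a step within the scatter, with no clear direction. Compound 4 is estimated at 10 nM, between 4 nM and 25 nM, meaning an expected step of a 1.1-fold higher number from compound 3 to compound 4 (0.06 log units; within the scatter).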

Compound 4, half-maximal inhibitory concentration: 8.1 nM
Beside the measured number, compound 4's estimate is 1.2-fold (0.09 log units) above it; low and high end bracket the measured number.
By their numbers in this assay, from the lowest: compounds 4 and 3 (each within the scatter of the next); then compounds 1 and 2 (each within the scatter of the next).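

In this assay, for the compounds shown here, this is the first exchange of a substituent on the aromatic carbon para to a large group, and trifluoromethyl in place of methoxy gives a 1.1-fold lower number from compound 3 to compound 4 (0.04 log units; within the scatter), so the two groups cannot be told apart at this position. The 4-(trifluoromethyl)phenyl group also stands clear of the two chains, with a 2.3-fold lower number from compound 1 to compound 4 (0.37 log units; beyond the scatter) against ethyl and a 3.1-fold lower number from compound 2 to compound 4 (0.49 log units; beyond the scatter) against pentyl, both modest and matching what the 4-methoxyphenyl group showed. No measurement at hand speaks to why methoxy and trifluoromethyl read alike here.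

The compounds shown leave open whether a plain hydrogen, an amine or a carboxylic acid on this aromatic carbon would read the same. They also leave open what either group would do elsewhere on the ring.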